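The source may report more compounds than this note shows. Statements on the series, on what has been measured and on what is new or still open speak of the compounds shown alone.

Compound 3 `C=CC(=O)Nc1cccc(Nc2ncnc(Nc3ccc(-c4ccc(C)nc4)cc3)n2)c1` gives 13800 nM in a functional assay on Raji cells (Homo sapiens) for antiproliferative activity, read by CCK-8 assay, with a stated time of 24 h (on this read-out higher numbers stand for weaker inhibition and lower numbers for stronger inhibition), the highest of the three numbers in hand. For the measured compounds named here, compound 1 `C=CC(=O)Nc1cccc(Nc2ncnc(Nc3ccc(-c4cccnc4)cc3)n2)c1` sits nearest, at 12400 nM in this assay, and the step of a 1.1-fold higher number from compound 1 to compound 3 (0.05 log units; within the scatter) is the only single-point change measured so far. Going by the values given here, compound 2 `CC#CC(=O)Nc1cccc(Nc2ncnc(Nc3ccc(C(=O)N4CCCCC4)cc3)n2)c1` stands furthest, at 4620 nM in this assay, a gap beyond the scatter; it differs from compound 3 in two places, so no single step can be drawn from it. Compound 4 `C=CC(=O)Nc1cccc(Nc2ncnc(Nc3ccc(OCCOC)cc3)n2)c1` is the next member: 2-methoxyethoxy in place of 6-methylpyridin-3-yl on an aromatic carbon. Among the compounds with values here, no measured step covers an exchange of this kind; the one step available swaps a hydrogen for a methyl on an aromatic carbon and lies within the scatter, so it says nothing about replacing the whole ring with a chain. The expectation for compound 4 in this assay is therefore a step of a 1.1-fold higher number from compound 3 to compound 4 (0.04 log units; within the scatter) that carries wide uncertainty in either direction. Compound 4 is estimated at 15000 nM in this assay, with a range from 5000 nM to 45000 nM.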

Compound 4, half-maximal inhibitory concentration: 105000 nM
For compound 4 the middle estimate is 7.0-fold (0.85 log units) below the measured one; the whole stated range lies below it.
By their numbers in this assay, from the lowest: compound 2; then compounds 1 and 3 (each within the scatter of the next); then compound 4.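

In this assay, for the compounds shown here, 2-methoxyethoxy in place of 6-methylpyridin-3-yl gives a 7.6-fold higher number from compound 3 to compound 4 (0.88 log units; beyond the scatter), the first step beyond the scatter at this aromatic carbon, para to a large group; the earlier change on the pyridine ring, a 1.1-fold higher number from compound 1 to compound 3 (0.05 log units; within the scatter), stayed within it. The exchange starting from pyridin-3-yl gives a step of similar reading, an 8.5-fold higher number from compound 1 to compound 4 (0.93 log units; beyond the scatter), so among these compounds the result does not depend on the methyl and the position responds to the exchange of ring for chain. Nothing available bears on the reason for this shift.

The compounds shown do not separate the loss of the aromatic ring from the entry of this particular chain. Open too, from the compounds shown here alone, is how a phenyl ring or a 2-(dimethylamino)ethoxy chain would read at this place.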